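The source may hold more compounds than are shown below. What is called first, only, known or untested is meant among the compounds shown, and "the series" means these compounds.

Three compounds have been tested in an ADME assay on HCT-116 cells (Homo sapiens) for cytotoxicity, read by MTT assay, with a stated time of 72 h; a lower number here means a stronger inhibitor, a higher number a weaker inhibitor:

Compound 1 `Cc1ccc(N2C(=O)C/C(=C\c3cccc(C(=O)Nc4cccc(F)c4)c3)C2=O)cc1` gives > 100000 nM, which is a limit of the assay rather than a number.
Compound 2 `CCOc1ccc(NC(=O)c2cccc(/C=C3\CC(=O)N(c4ccccc4)C3=O)c2)cc1` gives 84800 nM.
Compound 3 `CCCCCN1C(=O)C/C(=C\c2cccc(C(=O)Nc3cccc(F)c3)c2)C1=O` gives > 100000 nM, again a limit of the assay.

Among the measured compounds shown here, compound 2 therefore holds the only real number in this assay; the other two compounds sit at the limit of > 100000 nM in this assay, at which 2 of the 3 values shown sit. For the measured compounds named here, the single step between measured compounds that differ in one place, a step that the two limits leave unreadable from compound 1 to compound 3, starts and ends at that limit, so its size cannot be read. All three compounds share the same core, and all of them are weak in this assay.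

The next compound, compound 4 `CCc1cccc(NC(=O)c2cccc(/C=C3\CC(=O)N(c4ccccc4)C3=O)c2)c1`, is reached from compound 2 by one change: 3-ethylphenyl in place of 4-ethoxyphenyl on an amide-type nitrogen. Going by the values given here, no measured step touches this part of the molecule; the only step known changes the group on the ring nitrogen, not the amide aryl group, and it is unreadable anyway. There is thus nothing to suggest that the shift from 4-ethoxyphenyl to 3-ethylphenyl moves the value beyond the usual scatter.

Compound 4 is expected to stay close to compound 2, with an estimated step of a 1.1-fold higher number from compound 2 to compound 4 (0.03 log units; within the scatter). The estimate for compound 4 is 90000 nM, within a range from 30000 nM to 250000 nM, with a real chance that this assay again reports only a limit.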

Compound 4, half-maximal inhibitory concentration: 81200 nM
Estimate against measurement, compound 4: 1.1-fold (0.04 log units) above, within the range that was stated.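

In this assay, among the compounds shown here, 3-ethylphenyl in place of 4-ethoxyphenyl on the amide-type nitrogen gives a 1.0-fold lower number from compound 2 to compound 4 (0.02 log units; within the scatter), the first step in this set that can be read, and it lies within the scatter. At this position, then, the aryl group can lose the oxygen of its ethoxy chain and carry a different chain at a different ring position, and the two compounds still cannot be told apart in this test. The only other step, which changes the group on the ring nitrogen, cannot be read, and both of its compounds give no number, only a limit: the limit of > 100000 nM in this assay, at which 2 of the 4 values shown sit.

Two things changed at once in this swap, so a 4-ethylphenyl or a 3-ethoxyphenyl group would be needed to separate the effect of the chain from that of its ring position. From the compounds shown here alone, it also remains open whether a quite different group on this aryl ring, such as an amine or a carboxylic acid, would move the value beyond the scatter.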